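Amine substituent step toward compound 4, working notes

The compounds below may be only part of what the source reports. "The series", "measured", "known", "first", "only" and "open" are said of these compounds alone.

Measured so far in a functional assay on MCF7 cells (Homo sapiens) for inhibition, read by sulforhodamine B assay; a lower number here means a stronger inhibitor, a higher number a weaker inhibitor:

compound 1 `O=C1C(NC2CCCC2)=CC(=O)c2c1nc1n2[C@H]2OC[C@@H](O)[C@H]2OC1`: > 16000 nM, a limit of the assay
compound 2 `O=C1C=C(NC2CCCCC2)C(=O)c2c1nc1n2[C@H]2OC[C@@H](O)[C@H]2OC1`: > 8000 nM, a limit of the assay
compound 3 `COc1ccccc1NC1=CC(=O)c2nc3n(c2C1=O)[C@H]1OC[C@@H](O)[C@H]1OC3`: > 4000 nM, a limit of the assay

Compound 1 stands at a limit only, as the limit of > 16000 nM in this assay, at which 1 of the 3 values shown sits, records; no number is known for it. The same holds for compound 2 at the limit of > 8000 nM in this assay, at which 1 of the 3 values shown sits, and for compound 3 at the limit of > 4000 nM in this assay, at which 1 of the 3 values shown sits. Since all three values are limits, nothing in this assay orders compound 1 against compound 2 or compound 3.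

Compound 4 `COc1cccc(NC2=CC(=O)c3c(nc4n3[C@H]3OC[C@@H](O)[C@H]3OC4)C2=O)c1` is the next one to be measured. It differs from compound 1 by 3-methoxyphenyl in place of cyclopentyl on an amine nitrogen. Going by the values given here, the one measured step that bears on an aryl-for-cycloalkyl change on the amine nitrogen is a step that the two limits leave unreadable from compound 2 to compound 3, and its size is not readable because both ends are limits. Among the compounds with values here, no measured step therefore sets a direction or size for this assay here.

The expectation for compound 4 is that this assay again returns a limit rather than a number, so compound 4 is estimated at 12000 nM with a range from 2500 nM to 60000 nM. The step this estimate implies, an at least 1.3-fold lower number from compound 1 to compound 4 (0.12 log units; that floor lies within the scatter), is expected to be no step beyond the scatter.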

Compound 4, half-maximal inhibitory concentration: 3830 nM
Estimate against measurement, compound 4: 3.1-fold (0.50 log units) above; low and high end bracket the measured number.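

In this assay, going by these compounds alone, the change to 3-methoxyphenyl in place of cyclopentyl on this amine nitrogen gives an at least 4.1-fold lower number from compound 1 to compound 4 (0.62 log units; beyond the scatter) as the first step at this position that can be read. That step is only a floor, because compound 1 is recorded at a limit alone: the limit of > 16000 nM in this assay, at which 1 of the 4 values shown sits.

Compound 3, with 2-methoxyphenyl on the same nitrogen, stands only at the limit > 4000 nM and so shows that an aryl group there does not by itself yield a number.

On these data alone, what a plain phenyl or a benzyl group on this amine nitrogen would give stays open, as does whether the methoxy group has any part in the step. The steps among compound 1, compound 2 and compound 3 cannot be read, so those three remain unordered.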